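Working notes: from compound 3 to compound 4

The source may report more compounds than this note shows. Statements on the series, on what has been measured and on what is new or still open speak of the compounds shown alone.

Measured so far in an ADME assay on cells (Mus musculus, strain Balb/c) for cytotoxicity, read by MTT assay, with a stated time of 48 h; on this read-out higher numbers stand for lower toxicity in this test and lower numbers for higher toxicity in this test:
- compound 1 `O/N=C(\C=C\c1cccs1)c1ccc(Cl)cc1` gives 11800 nM
- compound 2 `O/N=C(\C=C\c1ccc(F)cc1)c1ccc(Cl)cc1` gives 11500 nM
- compound 3 `COc1ccc(/C=C/C(=N\O)c2ccc(Cl)cc2)cc1` gives 24300 nM

Compound 3 holds the highest of the three numbers in this assay; its nearest neighbour is compound 1, and compound 2 lies furthest from it. Among the measured compounds shown here, the one single-site step within the measured set is a 2.1-fold higher number from compound 2 to compound 3 (0.32 log units; beyond the scatter), a modest shift that lies beyond the scatter.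

Compound 4 `COc1ccc(/C=C/C(=N\O)c2ccc(Br)cc2)cc1` is the next member. It differs from compound 3 as follows: bromo in place of chloro on an aromatic carbon. For the measured compounds named here, no measured step exchanges one halogen for another at this position; the only measured step, a 2.1-fold higher number from compound 2 to compound 3 (0.32 log units; beyond the scatter), concerns a different group on the other ring, so it does not bear on the present change. With nothing in the series speaking for a shift either way, the expected step is a 1.0-fold lower number from compound 3 to compound 4 (0.01 log units; within the scatter), that is, no change beyond the scatter. Compound 4 is therefore estimated at 24000 nM in this assay, within a range of 12000 nM to 48000 nM.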

Compound 4, half-maximal cytotoxic concentration: 23700 nM
Compound 4: the middle estimate sits 1.0-fold (0.01 log units) above what was measured, within the range that was stated.
By their numbers in this assay, from the lowest: compounds 2, 1, 4 and 3 (each within the scatter of the next, the first and the last beyond it).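

In this assay, the step for bromo in place of chloro on an aromatic carbon, para to a large group, is a 1.0-fold lower number from compound 3 to compound 4 (0.01 log units; within the scatter), the only halogen exchange at this position among the compounds shown. With methoxy on the other ring, this position therefore takes either halogen without a change beyond the scatter, whereas the earlier single-site step concerned only the other ring. No supporting measurement bears on why the two halogens read alike.

The effect of an amine or a carboxylic acid at this position remains open, since the compounds shown carry only chloro or bromo there. Also open, going by these compounds, is whether the exchange would read the same with fluoro in place of methoxy on the other ring.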